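The source may report more compounds than this note shows. Statements on the series, on what has been measured and on what is new or still open speak of the compounds shown alone.

Measured in a functional assay on HOS cells (Homo sapiens) for antiproliferative activity, with a stated time of 72 h; on this read-out higher numbers stand for weaker inhibition and lower numbers for stronger inhibition:
- compound 1 `OC[C@H]1O[C@@H](n2cnc3c(NCc4cccc(F)c4)ncnc32)[C@H](O)[C@@H]1O`: > 166000 nM (a limit)
- compound 2 `OC[C@H]1O[C@@H](n2cnc3c(NCc4ccccc4Cl)ncnc32)[C@H](O)[C@@H]1O`: > 166000 nM (a limit)
- compound 3 `OC[C@H]1O[C@@H](n2cnc3c(NCc4ccc(Cl)c(Cl)c4)ncnc32)[C@H](O)[C@@H]1O`: > 166000 nM (a limit)

Compound 3 stands at > 166000 nM, which is a limit and not a number. Among the compounds with values here, it has no place in a ranking, since the series so far shows (the limit of > 166000 nM in this assay, at which 3 of the 3 values shown sit).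

Compound 4 `OC[C@H]1O[C@@H](n2cnc3c(NCc4ccc(F)c(Cl)c4)ncnc32)[C@H](O)[C@@H]1O` takes fluoro in place of chloro on an aromatic carbon of compound 3, ortho to a chloro group and para to a large group, so that 3,4-dichlorobenzyl becomes 3-chloro-4-fluorobenzyl: fluoro in place of chloro on an aromatic carbon.

The measured steps that bear on this change all alter the same aryl group: a step that the two limits leave unreadable from compound 1 to compound 2, a step that the two limits leave unreadable from compound 1 to compound 3 and a step that the two limits leave unreadable from compound 2 to compound 3. None of them has a readable size, so no measured size carries over to the new change, and no direction can be drawn from them. The working expectation for compound 4 rests on the fact that compound 3 and both of its neighbours sit at the same limit in this assay, and a further limit is the likeliest report.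

The expected change is a step that the limit leaves unreadable from compound 3 to compound 4, with no step beyond the scatter foreseen.

For compound 4 the estimated value is 170000 nM, with an expected range from 100000 nM to 300000 nM.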

Compound 4, half-maximal inhibitory concentration: > 166000 nM
Compound 4: only a limit was reported; the forecaster's own chance of this, stated with the estimate: 90%; the middle value is on the limit's open side.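

In this assay compound 4 gives > 166000 nM, which is a limit and not a number. Its steps to compound 1, compound 2 and compound 3 cannot be read, and these compounds cannot be ranked: the limit of > 166000 nM in this assay, at which 4 of the 4 values shown sit.

The compounds shown leave open whether any benzyl group on the shared core gives a measurable value in this assay.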